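The source may report more compounds than this note shows. Statements on the series, on what has been measured and on what is new or still open speak of the compounds shown alone.

Compound 1, `COc1ccc2occ(CSC(=S)N3CCOCC3)c(=O)c2c1`: 4800 nM
Compound 2, `COc1ccc2occ(CSC(=S)N3CCCCC3)c(=O)c2c1`: 4300 nM
Compound 3, `CCOC(=O)c1cc(=O)c2cc(CSC(=S)N3CCCCC3)ccc2o1`: 3400 nM

All three were tested in a functional assay on HEp-2 cells (Homo sapiens) for antiproliferative activity, read by MTT assay, with a stated time of 72 h (on this read-out higher numbers stand for weaker inhibition and lower numbers for stronger inhibition), which reports the concentration at which growth of the cells is inhibited to the stated degree. Compound 1 and compound 2 share one core; compound 3 is built on another core, and the difference between the two cores is not broken down here. Compound 2 and compound 1 differ in one place only: morpholin-4-yl in place of piperidin-1-yl on a thiocarbonyl carbon. This change gave a 1.1-fold higher number from compound 2 to compound 1 (0.05 log units; within the scatter), so on this core the two groups cannot be told apart. The values of compound 3 and compound 2 lie within the scatter of each other, and so do those of compound 3 and compound 1.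

Compound 4, `CCOC(=O)c1cc(=O)c2cc(CSC(=S)N3CCOCC3)ccc2o1`, has not yet been measured. It differs from compound 3 in the same way, and the place is the same word for word: morpholin-4-yl in place of piperidin-1-yl on a thiocarbonyl carbon. Among the compounds shown this change occurs twice in all, once measured and once awaiting measurement, so the earlier step is the only guide to the new one. A step of similar size is expected here, a 1.1-fold higher number from compound 3 to compound 4 (0.04 log units; within the scatter), because a 1.1-fold higher number from compound 2 to compound 1 (0.05 log units; within the scatter) lay within the scatter. Compound 4 is therefore estimated at 3700 nM in this assay, with a likely range from 2200 nM to 6500 nM.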

Compound 4, half-maximal inhibitory concentration: > 25000 nM
Compound 4 was reported as a limit; the forecaster's own chance of this, stated with the estimate: 2%; middle value at least 6.7-fold (0.82 log units) away from the limit.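

On the core of compound 3, putting morpholin-4-yl in place of piperidin-1-yl on a thiocarbonyl carbon gave an at least 7.3-fold higher number from compound 3 to compound 4 (0.86 log units; beyond the scatter) in this assay. Compound 4 gives > 25000 nM, which is a limit of the assay and not a number. With only one pair on each core, this shows that the change does not carry over at the same size from one core to the other, but it does not show which difference between the cores lies behind the gap, or how large the step on the core of compound 3 really is: the same change on two cores in this assay, a 1.1-fold higher number (0.05 log units; within the scatter) from compound 2 to compound 1 and an at least 7.3-fold higher number (0.86 log units; beyond the scatter) from compound 3 to compound 4, at least 6.5-fold (0.81 log units) apart, beyond the scatter of two such steps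

The compounds shown leave open which part of the core of compound 3 makes the swap matter so much there, and a carboxylic acid or an amide in place of its ethyl ester would help to test whether the ester is involved. They also leave open whether the sharp step belongs to morpholin-4-yl alone or would appear with other amines on the thiocarbonyl carbon on that core, such as pyrrolidin-1-yl or 4-methylpiperazin-1-yl.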